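Swapping cyclopropyl for (2-(dimethylamino)ethyl)carbamoyl on a shared core

The source may report more compounds than this note shows. Statements on the series, on what has been measured and on what is new or still open speak of the compounds shown alone.

Measured so far:
Compound 1, `COc1ncc(-c2ccc3nc(NC4CC4)sc3c2)cc1NS(=O)(=O)c1ccc(F)cc1`: 450 nM
Compound 2, `CCN(CC)CCNC(=O)Nc1nc2ccc(-c3cnc(OC)c(NS(=O)(=O)c4ccc(C)cc4)c3)cc2s1`: 170 nM
Compound 3, `O=S(=O)(Nc1cc(-c2ccc3nc(NC4CC4)sc3c2)cnc1Cl)c1ccc(F)cc1`: "not determined" (no result reported)

In a functional assay on MCF7 cells (Homo sapiens) for antiproliferative activity, read by MTT assay, with a stated time of 72 h (a higher number here means a weaker inhibitor, a lower number a stronger inhibitor), compound 1 gives 450 nM, the highest of the two numbers available, so it is the weaker of the two measured inhibitors. Compound 2 gives 170 nM in this assay, a lower number, and the gap between compound 1 and compound 2 lies beyond the usual scatter. For compound 3 the entry in this assay reads "not determined" (no result reported), so no number is available for it.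

The new compound 4, `COc1ncc(-c2ccc3nc(NC(=O)NCCN(C)C)sc3c2)cc1NS(=O)(=O)c1ccc(F)cc1`, differs from compound 1 in one place: (2-(dimethylamino)ethyl)carbamoyl in place of cyclopropyl on a nitrogen on an aromatic ring

Going by the values given here, no pair of measured compounds differs in exactly this one place, so the size of the step cannot be read off directly. Compound 2, which carries a longer chain on the same nitrogen, gives the lower number in this assay, which suggests a moderate move toward a stronger inhibitor. The expected step of a 2.3-fold lower number from compound 1 to compound 4 (0.35 log units; beyond the scatter) is toward a lower number, beyond the scatter but not large. For compound 4 the estimated value in this assay is 200 nM, with a range from 80 nM to 500 nM.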

Compound 4, half-maximal inhibitory concentration: 500 nM
Estimate against measurement, compound 4: 2.5-fold (0.40 log units) below; the measured number falls inside the stated range.
By their numbers in this assay, from the lowest: compound 2; then compounds 1 and 4 (each within the scatter of the next).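

In this assay, putting (2-(dimethylamino)ethyl)carbamoyl in place of cyclopropyl on a nitrogen on an aromatic ring gives a 1.1-fold higher number from compound 1 to compound 4 (0.05 log units; within the scatter), so this read-out does not separate the two compounds. At this position, then, a three-membered ring of 3 heavy atoms and an open group of 8 heavy atoms, with a carbonyl and a terminal amine, give numbers that cannot be told apart. No measurement at hand speaks to the reason for this result.

As far as these compounds go, it remains open whether other groups on this nitrogen, such as a plain methyl or a longer chain ending in a carboxylic acid, would also leave the number within the scatter. Compound 3, which carries chlorine where compound 1 carries methoxy, has no number, so that step cannot be read.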